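A few compounds are considered here, and "the series" means these few. Any claim that something is new, unique, unknown or untested is made for them only; others in the source may bear on it.

Measured so far in a functional assay on HeLa cells (Homo sapiens) for antiproliferative activity, read by MTT assay, with a stated time of 48 h; on this read-out higher numbers stand for weaker inhibition and lower numbers for stronger inhibition:
compound 1 `COc1ccc(-c2cn3cc(C4=CCN(C(=O)c5ccc(Cl)cc5)CC4)ccc3n2)cc1OC`: 12200 nM
compound 2 `COc1ccc(-c2cn3cc(C4=CCN(C(=O)C(C)(C)C)CC4)ccc3n2)cc1OC`: 5480 nM
compound 3 `COc1ccc(-c2cn3cc(C4=CCN(S(=O)(=O)C5CCCC5)CC4)ccc3n2)cc1OC`: 6470 nM

Compound 2 gives the lowest of the three numbers in this assay. Compound 3 sits nearest, and the two lie within the scatter of each other, so no order between them can be read. Going by the values given here, compound 1 stands furthest, and a 2.2-fold lower number from compound 1 to compound 2 (0.35 log units; beyond the scatter) is the one step in this set that lies beyond the scatter.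

Compound 4 `COc1ccc(-c2cn3cc(C4=CCN(S(=O)(=O)c5ccccc5)CC4)ccc3n2)cc1OC` is not yet measured. Relative to compound 2 the change is phenylsulfonyl in place of (tert-butyl)carbonyl on an amine nitrogen in a ring.

Among the compounds with values here, two measured steps bear on it. The exchange of an acyl group for a sulfonyl group on the same ring nitrogen, a 1.2-fold higher number from compound 2 to compound 3 (0.07 log units; within the scatter), stayed within the scatter. The exchange of an aryl group for tert-butyl on the carbonyl carbon, a 2.2-fold lower number from compound 1 to compound 2 (0.35 log units; beyond the scatter), gave a modestly lower number, so putting an aromatic ring back in place of the tert-butyl points toward a higher number. Compound 4 combines both changes. Within the data shown here, the expectation is therefore a small rise, a 1.5-fold higher number from compound 2 to compound 4 (0.16 log units; within the scatter), no larger than the step between compound 1 and compound 2 and possibly within the scatter. Compound 4 is estimated at 8000 nM, with a range of 3500 nM to 18000 nM.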

Compound 4, half-maximal inhibitory concentration: 12600 nM
For compound 4 the middle estimate is 1.6-fold (0.20 log units) below the measured one; the measured number falls inside the stated range.
By their numbers in this assay, from the lowest: compounds 2, 3, 1 and 4 (each within the scatter of the next, the first and the last beyond it).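

In this assay the group on the amine nitrogen in the ring now gives a sulfonyl step beyond the scatter, with a 2.3-fold higher number from compound 2 to compound 4 (0.36 log units; beyond the scatter) set against the within-scatter step to the cyclopentylsulfonyl of compound 3, so exchanging carbonyl for sulfonyl does not by itself set the number. Compound 1 and compound 4 carry an aromatic ring on different linking groups and cannot be separated, with a 1.0-fold higher number from compound 1 to compound 4 (0.01 log units; within the scatter) on record, and both lie beyond the scatter of the tert-butyl compound 2, but compound 3 goes against any clean split by aromatic ring, since a 1.9-fold higher number from compound 3 to compound 4 (0.29 log units; within the scatter) stays within the scatter and compound 3 also lies within the scatter of compound 2. No measurement at hand accounts for these differences.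

On these data alone, whether the aromatic ring itself or only the size of the group goes with the higher numbers stays open, as phenyl and cyclopentyl on the sulfonyl sulfur cannot be ordered. The compounds shown also leave open how a small methylsulfonyl, an amine on a longer chain or a carboxylic acid on the phenyl ring would read at this nitrogen, and whether any group here moves the numbers far from this range.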